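Fluoro to methyl on the aryl ring of compound 3

The source may hold more compounds than are shown below. What is called first, only, known or untested is meant among the compounds shown, and "the series" means these compounds.

Of the compounds shown here, three sharing one core have been tested in a functional assay with Homo sapiens as the target; on this read-out lower numbers stand for stronger inhibition and higher numbers for weaker inhibition. Compound 1 `Cc1c(C(=O)Nc2ccc(C(F)(F)F)cc2)cnn1-c1ccc(F)c(Cl)c1` gives 1300 nM. Compound 2 `COc1ccc(-n2ncc(C(=O)Nc3ccc(C(F)(F)F)cc3)c2C)cc1` gives 340 nM, and compound 3 `Cc1c(C(=O)Nc2ccc(C(F)(F)F)cc2)cnn1-c1cccc(F)c1` gives 3100 nM. Compound 3 stands at the highest number of the three: the steps of a 2.4-fold higher number from compound 1 to compound 3 (0.38 log units; beyond the scatter) and a 9.1-fold higher number from compound 2 to compound 3 (0.96 log units; beyond the scatter) both lie beyond the scatter, and a 3.8-fold lower number from compound 1 to compound 2 (0.58 log units; beyond the scatter) separates the other two. Compound 4 `Cc1cccc(-n2ncc(C(=O)Nc3ccc(C(F)(F)F)cc3)c2C)c1` differs from compound 3 in one place: methyl in place of fluoro on an aromatic carbon. The same difference, cut one bond further out, reads 3-fluorophenyl to 3-methylphenyl. For the measured compounds named here, no measured step trades fluoro for methyl; all three steps exchange the whole aryl group on the aromatic nitrogen, and each is of modest size. Going by the values given here, they show only that this ring shifts the number by modest amounts, in either direction. A small step is therefore expected, with no direction favoured, so compound 4 is estimated at 2500 nM, between 1000 nM and 6500 nM, which is expected to mean a 1.2-fold lower number from compound 3 to compound 4 (0.09 log units; within the scatter).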

Compound 4, half-maximal inhibitory concentration: 2500 nM
Beside the measured number, compound 4's estimate shows no gap at the digits printed; measured number inside the range.
By their numbers in this assay, from the lowest: compound 2; then compounds 1, 4 and 3 (each within the scatter of the next, the first and the last beyond it).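

In this assay, with a 1.2-fold lower number from compound 3 to compound 4 (0.09 log units; within the scatter) the methyl and fluoro groups cannot be told apart on this aromatic carbon, meta to a large group. With a 1.9-fold higher number from compound 1 to compound 4 (0.28 log units; within the scatter) the 3-methylphenyl group also cannot be separated from the 3-chloro-4-fluorophenyl group, whereas with a 7.4-fold higher number from compound 2 to compound 4 (0.87 log units; beyond the scatter) it stands clearly apart from the 4-methoxyphenyl group, so not every exchange of the aryl group leaves the number in the same place. No measurement at hand gives a cause for any of these results.

The compounds shown leave open whether any group on this aromatic carbon can move the number beyond the scatter. An amine, a carboxylic acid or a longer chain there would show whether this position responds to a larger change than fluoro to methyl.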